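A few compounds are considered here, and "the series" means these few. Any claim that something is new, unique, unknown or untested is made for them only; others in the source may bear on it.

Among the compounds with values here, compound 2 `N=C(N)NC(=O)C[C@@H]1CCCc2cc(S(=O)(=O)c3cccc(F)c3)ccc21` is, of the two measured members, the one with the higher number in an assay on isolated protein for displacement of a labelled ligand from 5-hydroxytryptamine receptor 6 (Homo sapiens); on this read-out lower numbers stand for stronger inhibition and higher numbers for weaker inhibition: compound 2 gives 0.631 nM, while compound 1 `O=S(=O)(c1cccc(F)c1)c1ccc2c(c1)CCC[C@H]2CN1CC(O)C1` gives 0.1 nM. Within the data shown here, the only measured step, a 6.3-fold higher number from compound 1 to compound 2 (0.80 log units; beyond the scatter), replaces the four-membered ring substituent of compound 1 with an open chain and is described as modest, so the position on the saturated chain carbon bound to the saturated ring carbon accepts a change of group with a limited cost.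

Compound 3 `CN(C[C@@H]1CCCc2cc(S(=O)(=O)c3cccc(F)c3)ccc21)C(N)=O` continues from compound 2 at that same place: a group of 5 heavy atoms (2 carbon, 2 nitrogen, 1 oxygen; no ring) in place of a group of 6 heavy atoms (2 carbon, 3 nitrogen, 1 oxygen; no ring), on a saturated chain carbon bound to a saturated ring carbon. Among the measured compounds shown here, no measured pair shows this particular exchange, so the step of a 6.3-fold higher number from compound 1 to compound 2 (0.80 log units; beyond the scatter) is the only guide to how strongly this assay answers to changes at this position. Given that guide, a step of at most the same order is expected, with no strong reason to favour either direction, and the estimated step is a 1.6-fold higher number from compound 2 to compound 3 (0.20 log units; within the scatter). Compound 3 is therefore expected to show about 1 nM in this assay, with a likely range from 0.25 nM to 4 nM.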

Compound 3, inhibition constant: 39.8 nM
For compound 3 the middle estimate is 40-fold (1.60 log units) below the measured one; the measured number lies above the stated range.
By their numbers in this assay, from the lowest: compound 1; then compound 2; then compound 3.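

In this assay, within the data shown here, the exchange of the open chain of compound 2 for carbamoyl(methyl)amino gives a 63-fold higher number from compound 2 to compound 3 (1.80 log units; beyond the scatter) on the same saturated chain carbon bound to a saturated ring carbon, so this place is far less forgiving than the single earlier step suggested. Set against the 3-hydroxyazetidin-1-yl of compound 1, the same carbamoyl(methyl)amino gives a 400-fold higher number from compound 1 to compound 3 (2.60 log units; beyond the scatter) on an unchanged core, which makes compound 3 the weakest of the three, with both of its steps beyond the scatter and both large. Nothing offered here accounts for the size of these steps.

As far as these compounds go, it remains open whether the methyl on the nitrogen of carbamoyl(methyl)amino matters, which the unmethylated urea would test, and whether the fall in this assay follows the shorter reach of this group, which a longer chain carrying the same urea would test. From the compounds shown here alone, it is equally open where a simple tertiary amine, a primary amide or a carboxylic acid at this place would fall relative to compound 1 and compound 3.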